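The source may hold more compounds than are shown below. What is called first, only, known or untested is meant among the compounds shown, and "the series" means these compounds.

Compound 2 `CCn1ncc(OCc2nnc(-c3ccccc3)o2)c(Cl)c1=O` is the starting point. In a functional assay on the whole organism for inhibition, with Mythimna separata as the target, with a stated time of 5 days (a higher number here means that more compound is needed for the effect, a lower number that less compound is needed), compound 2 gives > 300 ug/mL, which is a limit of the assay rather than a number, so compound 2 sits at the limit of > 300 ug/mL in this assay, at which 1 of the 2 values shown sits. Compound 1 `CC(C)(C)n1ncc(OCc2nnc(-c3ccc(Cl)cc3)s2)c(Cl)c1=O` is a different molecule in several places; in this assay compound 1 gives 106 ug/mL. Compound 3 `CCn1ncc(OCc2nnc(-c3ccc(F)cc3)o2)c(Cl)c1=O` differs from compound 2 by fluoro in place of hydrogen on an aromatic carbon. Going by the values given here, no measured step covers this change, so the expected step of a number no higher from compound 2 to compound 3 (the limit leaves the size open) is none beyond the scatter, and a limit again is the likelier outcome. Compound 3 is therefore estimated at 300 ug/mL, between 100 ug/mL and 1000 ug/mL.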

Compound 3, half-maximal effective concentration: > 300 ug/mL
Compound 3 was reported as a limit (the forecaster's own chance of this, stated with the estimate: 65%); the middle value lies on the limit itself.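

Compound 2 and compound 3 both give a limit rather than a number in this assay, so no step between them can be read: the limit of > 300 ug/mL in this assay, at which 2 of the 3 values shown sit.

As far as these compounds go, whether going from phenyl to 4-fluorophenyl shifts the effect at all remains open.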